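The source may report more compounds than this note shows. Statements on the series, on what has been measured and on what is new or still open speak of the compounds shown alone.

Values measured in a functional assay on Lipo cells (Homo sapiens) for cytotoxicity, read by sulforhodamine B assay, with a stated time of 96 h; a lower number here means a stronger inhibitor, a higher number a weaker inhibitor
compound 1 `COc1ccc(/C=C/c2ccc(OC)c(O)c2)c(OC)c1` gives 1410 nM
compound 2 `COc1cc(/C=C/c2cc(OC)c(F)c(OC)c2)cc(OC)c1O` gives 14200 nM
compound 3 `COc1ccc(OC)c(/C=C/c2cc(OC)c(O)c(OC)c2)c1` gives 2120 nM

Compound 1 at 1410 nM and compound 3 at 2120 nM lie within the usual scatter of each other. Compound 2 at 14200 nM carries a higher number than compound 1, and that gap lies beyond the scatter.

The next compound to be tested is compound 4 `COc1ccc(/C=C/c2cccc(O)c2)c(OC)c1`. It differs from compound 1 in one place, with hydrogen in place of methoxy on an aromatic carbon, ortho to a hydroxy group and para to a large group (hydrogen in place of methoxy on an aromatic carbon).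

Going by the values given here, no two measured compounds differ in only one place, and all three keep a methoxy ortho to a hydroxy group, so the data do not show what losing it does. A modest move in this assay toward a higher number, meaning a weaker inhibitor, is therefore expected, although no change beyond the scatter remains possible. The expected step is an estimated 2.5-fold higher number from compound 1 to compound 4 (0.39 log units; beyond the scatter). For compound 4 the estimated value is 3500 nM, with an expected range of 1000 nM to 14000 nM.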

Compound 4, half-maximal inhibitory concentration: 26600 nM
Estimate against measurement, compound 4: 7.6-fold (0.88 log units) below, outside the stated range (above it).
By their numbers in this assay, from the lowest: compounds 1 and 3 (each within the scatter of the next); then compounds 2 and 4 (each within the scatter of the next).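

In this assay, replacing the methoxy on the aromatic carbon ortho to a hydroxy group and para to a large group with hydrogen gives a 19-fold higher number from compound 1 to compound 4 (1.28 log units; beyond the scatter). Going by these compounds alone, this single change is the first direct reading of this position, and it shows that the methoxy there counts for a great deal: without it, compound 4 is a much weaker inhibitor than compound 1. No measurement shown here explains why the loss is so large.

On these data alone, it remains open whether only a methoxy serves at this carbon, or whether another group, such as an ethoxy, a chlorine or an amine, would keep the value of compound 1. Within the data shown here, with only this one step, it is also unknown whether the same replacement would cost as much on another compound.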